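Removing one methyl from the 2-methylbutyl amide

The source may hold more compounds than are shown below. What is called first, only, known or untested is meant among the compounds shown, and "the series" means these compounds.

Values so far in an ADME assay on microsomes from liver (Macaca fascicularis) for metabolic stability, using NADPH, with a stated time of 30 min, tested at 1 uM (a higher number here means that more of the compound is left, a lower number that less of the compound is left), are these.
Compound 1 `CC(C)[C@H](C[C@H](O)[C@@H](N)CN1CC(=O)N(c2ccccc2Cl)CC1(C)C)C(=O)NC1CCCCC1` gives 17.5%
Compound 2 `CC[C@H](C)CNC(=O)[C@@H](C[C@H](O)[C@@H](N)CN1CC(=O)N(c2cc(F)ccc2Cl)CC1(C)C)C(C)C` gives 1.9%
Compound 3 `CC[C@H](C)CNC(=O)[C@@H](C[C@H](O)[C@@H](N)CN1CC(=O)N(c2ccccc2Cl)CC1(C)C)C(C)C` gives 8.4%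

Compound 3 stands second of the three numbers, yet its gaps to the other two lie within the usual scatter. Compound 4 `CCCCNC(=O)[C@@H](C[C@H](O)[C@@H](N)CN1CC(=O)N(c2ccccc2Cl)CC1(C)C)C(C)C` differs from it by hydrogen in place of methyl on a saturated chain carbon bound to two saturated chain carbons and the same change reads 2-methylbutyl to butyl.

Among the compounds with values here, two measured steps bear on this. The closer is a number 9.1 percentage points lower from compound 1 to compound 3 (within the scatter) for 2-methylbutyl in place of cyclohexyl on an amide-type nitrogen, a larger swap at the same nitrogen that still stayed within the scatter. The other is a number 6.5 percentage points higher from compound 2 to compound 3 (within the scatter) for hydrogen in place of fluoro on an aromatic carbon, which is a different place in the molecule and so offers only a rough idea of how far such numbers move.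

Losing a single methyl is therefore not expected to shift the number beyond the scatter in either direction. The expected step is a number 1.6 percentage points higher from compound 3 to compound 4 (within the scatter) and this estimate carries no firm direction. For compound 4 the estimated value is 10% with 3% to 24% as the expected range.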

Compound 4, percent of the compound remaining: 39.2%
Estimate against measurement, compound 4: 29.2 percentage points below; measured number above the stated range.
By their numbers in this assay, from the lowest: compounds 2, 3 and 1 (each within the scatter of the next, the first and the last beyond it); then compound 4.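

In this assay, within the data shown here, the methyl on this saturated chain carbon proves to matter far more than the earlier steps hinted, with hydrogen in its place giving a number 30.8 percentage points higher from compound 3 to compound 4 (beyond the scatter) as the result of that one small change. The group on the amide-type nitrogen can clearly move this number, as butyl in place of cyclohexyl gives a number 21.7 percentage points higher from compound 1 to compound 4 (beyond the scatter) in a comparison where the earlier swap of cyclohexyl for 2-methylbutyl stayed within the scatter. Nothing available here explains why removing this methyl has so large an effect.

On these data alone, whether the unbranched form or the chain length counts most remains open, and a propyl or pentyl chain on the same nitrogen would help separate the two. As far as these compounds go, it also remains open whether butyl would give a similar step in the fluoro-bearing compound 2.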